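From propylsulfonyl to benzoyl: an estimate of plasma level

The source may hold more compounds than are shown below. What is called first, only, known or untested is meant among the compounds shown, and "the series" means these compounds.

Compound 1 `Cc1cc(C)c(NC(=O)c2sccc2S(=O)(=O)Nc2onc(C)c2Cl)c(C)c1CO` gives 5110 nM
Compound 2 `COc1c(C)cc(C)c(NC(=O)c2sccc2S(=O)(=O)Nc2onc(C)c2Cl)c1C` gives 8510 nM
Compound 3 `CCCS(=O)(=O)c1cc(C)cc(C)c1NC(=O)c1sccc1S(=O)(=O)Nc1onc(C)c1Cl` gives 5450 nM

In an in vivo ADME assay on the whole organism (plasma) for pharmacokinetics, with Rattus norvegicus as the target, at a dose of 50 mg/kg by the oral route (a lower number here means less compound in the circulation, a higher number more compound in the circulation at the dose given), compound 3 gives 5450 nM and lies within the scatter of both compound 1 and compound 2, so these three numbers form a single group with no real ranking.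

Compound 4 `Cc1cc(C)c(NC(=O)c2sccc2S(=O)(=O)Nc2onc(C)c2Cl)c(C(=O)c2ccccc2)c1` has benzoyl in place of propylsulfonyl on an aromatic carbon, ortho to a large group and meta to two methyl groups (benzoyl in place of propylsulfonyl on an aromatic carbon).

Among the measured compounds shown here, no measured compound carries benzoyl, so the evidence is indirect. For the measured compounds named here, the only measured step, methoxy in place of hydroxymethyl (a 1.7-fold higher number from compound 1 to compound 2 (0.22 log units; within the scatter)), stayed within the scatter, and it is a different exchange. The three measured compounds differ in this kind of group yet remain close together, so no direction can be argued. The step expected in this assay is a 1.2-fold lower number from compound 3 to compound 4 (0.08 log units; within the scatter) and no larger than the scatter. On these data alone, since benzoyl is untested here, the range is kept wide. The estimate for compound 4 is 4500 nM (expected range 1500 nM to 11000 nM).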

Compound 4, maximal plasma concentration: 63100 nM
Beside the measured number, compound 4's estimate is 14-fold (1.15 log units) below it; measured number above the stated range.
By their numbers in this assay, from the lowest: compounds 1, 3 and 2 (each within the scatter of the next); then compound 4.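

Going from propylsulfonyl to benzoyl in this assay gives a 12-fold higher number from compound 3 to compound 4 (1.06 log units; beyond the scatter) and is the only step shown that lies beyond the scatter. The earlier compounds shown here stayed so close together that they gave no sign of such a change, but this result shows that the group on an aromatic carbon, ortho to a large group and meta to two methyl groups, can make a large difference to the plasma level. No supporting measurement is available to say why the level differs so much.

On these data alone, it remains open whether the carbonyl or the aromatic ring of benzoyl matters more, and a plain phenyl or an acetyl group at the same place would help separate the two. The effect of an amine or a carboxylic acid there is also unknown.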